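From Chloro to Fluoro: Another Limit Expected

The source may report more compounds than this note shows. Statements on the series, on what has been measured and on what is new or still open speak of the compounds shown alone.

Three measured compounds share one core. Compound 1 `O=C(O)Cc1sc(Nc2ccccc2)nc1-c1ccc(F)cc1`, compound 2 `O=C(O)Cc1sc(-c2ccccc2)nc1-c1ccc(F)cc1` and compound 3 `O=C(O)Cc1sc(Cc2ccccc2)nc1-c1ccc(Cl)cc1` were tested in an in vitro functional assay on HEK285-7 cells for antagonist activity at prostaglandin D2 receptor 2 (Homo sapiens), read by BRET and beta-arrestin recruitment; on this read-out higher numbers stand for larger maximal responses and lower numbers for smaller maximal responses. Compound 1 reaches > 70%, which is a limit of the assay rather than a number. Compound 2 likewise gives > 70%, a limit. Compound 3 sits at > 70%, again a limit. For the measured compounds named here, the only step between measured compounds, a step that the two limits leave unreadable from compound 1 to compound 2, is thus unreadable, since (the limit of > 70% in this assay, at which 3 of the 3 values shown sit). Compound 4 `O=C(O)Cc1sc(Cc2ccccc2)nc1-c1ccc(F)cc1` differs from compound 3 by fluoro in place of chloro on an aromatic carbon. Going by the values given here, no measured step covers this change, so nothing here fixes its size or direction. Compound 4 is therefore expected to stay close to compound 3, with an estimated step that the limit leaves unreadable from compound 3 to compound 4. Compound 4 is estimated at 85%, between 65% and 100%.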

Compound 4, largest response reached (reported as efficacy), in percent of the reference or control that the assay uses: 30%
For compound 4 the middle estimate is 55 percentage points above the measured one; measured number outside the range, below it.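

In this assay, changing 4-chlorophenyl to 4-fluorophenyl while the benzyl group stays in place gives a number at least 40 percentage points lower from compound 3 to compound 4 (beyond the scatter), so this swap of a single atom can matter a great deal at this position. Fluoro alone does not decide the outcome: with 4-fluorophenyl kept, the group on the other side of the core also counts, giving a number at least 40 percentage points lower from compound 2 to compound 4 (beyond the scatter) and a number at least 40 percentage points lower from compound 1 to compound 4 (beyond the scatter). Each step shows only a minimum size, because its starting compound sits at a limit: the limit of > 70% in this assay, at which 3 of the 4 values shown sit.

As far as these compounds go, it remains open whether bromo or methoxy in the same place would behave like chloro or like fluoro. From the compounds shown here alone, it also remains open whether chloro and fluoro would differ this much with phenyl or anilino in place of benzyl.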